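The source may report more compounds than this note shows. Statements on the series, on what has been measured and on what is new or still open speak of the compounds shown alone.

Measured compounds in an assay on CHO cells for displacement of a labelled ligand from adenosine receptor A3 (Homo sapiens), read by scintillation counting, tested at 1 uM; on this read-out lower numbers stand for less inhibition and higher numbers for more inhibition at the one concentration tested (going by the name of the read-out):
- compound 1, `CCc1nc(N)c2nn(-c3ccccc3)cc2n1`, gives 38%
- compound 2, `CC(C)Cc1nc(N)c2nn(-c3ccccc3)cc2n1`, gives 13%
- compound 3, `Nc1nc(Cc2ccc(Cl)cc2)nc2cn(-c3ccccc3)nc12`, gives 11%

Compound 3 has the lowest of the three numbers. Its nearest neighbour is compound 2, and the step of a number 2 percentage points lower from compound 2 to compound 3 (within the scatter) lies within the scatter, so the two cannot be told apart. Compound 1 is furthest away, with a number 27 percentage points lower from compound 1 to compound 3 (beyond the scatter).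

Compound 4, `Nc1nc(/C=C/c2ccccc2)nc2cn(-c3ccccc3)nc12`, differs from compound 3 in one place: 2-phenylethenyl in place of 4-chlorobenzyl on an aromatic carbon.

For the measured compounds named here, three measured steps touch the same carbon. Replacing the smallest group with a larger one lowered inhibition in both a number 25 percentage points lower from compound 1 to compound 2 (beyond the scatter) and a number 27 percentage points lower from compound 1 to compound 3 (beyond the scatter), while exchanging one larger group for another gave a number 2 percentage points lower from compound 2 to compound 3 (within the scatter), within the scatter. Compound 4 again carries a group of the same counted size as that of compound 3, so the expected step is small: a number 4 percentage points higher from compound 3 to compound 4 (within the scatter), that is, none beyond the scatter. For compound 4 in this assay the estimated value is 15%, with a range from 3% to 35%.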

Compound 4, a percentage reported as inhibition, at one concentration (the size of the read-out at that concentration, not a potency): 25%
Compound 4: middle estimate off by 10 percentage points, on the low side; the range from low to high includes it.
By their numbers in this assay, from the lowest: compounds 3 and 2 (each within the scatter of the next); then compound 4; then compound 1.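

In this assay, the group on this carbon matters beyond its counted size: 2-phenylethenyl and 4-chlorobenzyl each have 8 heavy atoms, yet exchanging them gives a number 14 percentage points higher from compound 3 to compound 4 (beyond the scatter). The 2-phenylethenyl group also stands apart from isobutyl, with a number 12 percentage points higher from compound 2 to compound 4 (beyond the scatter), but it does not restore the level seen with ethyl, with a number 13 percentage points lower from compound 1 to compound 4 (beyond the scatter), so the larger groups on this carbon no longer form a single flat low level. No measurement shown here accounts for these differences.

The exchange removes the chlorine and adds a double bond outside aromatic rings at once, so the compounds shown leave open which of the two changes carries the step. A plain benzyl or a 2-phenylethyl group would separate them, and an amine on this carbon remains an open case.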